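Bromo in place of nitro on the triazole aryl of compound 3

This account rests on a few compounds, and the source may have more. Where it says the series, first, only, none or still open, it means among the compounds named here.

Compound 3 `O=C(N1CCC=C[C@@H]1COCc1ccccc1)n1cc(-c2ccc([N+](=O)[O-])cc2)nn1` stands together with compound 1 `O=C(N1C[C@H](O)C=C[C@@H]1Cc1ccccc1)n1cc(-c2ccc(-c3ccccc3)cc2)nn1` at the low end of the three numbers measured. In an assay on HEK293 cells for inhibition of diacylglycerol lipase-alpha (Homo sapiens), read by colorimetric assay, with stated times of 30 min, 60 s and 20 min (a higher number here means a weaker inhibitor, a lower number a stronger inhibitor), compound 3 gives 15.9 nM; compound 1 gives 15.9 nM, no change at the digits printed and within the scatter. Compound 2 `O=C(N1CCC=C[C@@H]1COCc1ccccc1)n1cc(-c2ccccc2)nn1`, the unsubstituted phenyl member of the same core, is the furthest from compound 3: in this assay compound 2 gives 158 nM. For the measured compounds named here, the single one-place step in the set runs from this compound: a 9.9-fold lower number from compound 2 to compound 3 (1.00 log units; beyond the scatter), a modest but real gain on putting the nitro in.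

Compound 4 `O=C(N1CCC=C[C@@H]1COCc1ccccc1)n1cc(-c2ccc(Br)cc2)nn1` carries bromo in place of nitro on an aromatic carbon. Going by the values given here, no measured pair exchanges nitro for bromo, so the only step that bears on this change is a 9.9-fold lower number from compound 2 to compound 3 (1.00 log units; beyond the scatter), which shows how much the nitro added over hydrogen at the same position; whether bromo keeps that gain is not known from these numbers. The working expectation is a number for compound 4 that lies above compound 3 but well short of compound 2, so compound 4 is estimated at 40 nM in this assay, range 15 nM to 120 nM. That estimate means a 2.5-fold higher number from compound 3 to compound 4 (0.40 log units; beyond the scatter).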

Compound 4, half-maximal inhibitory concentration: 15.9 nM
Beside the measured number, compound 4's estimate is 2.5-fold (0.40 log units) above it; measured number inside the range.
By their numbers in this assay, from the lowest: compounds 1, 3 and 4 (each within the scatter of the next); then compound 2.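

In this assay the gain over hydrogen at this place, on an aromatic carbon para to a large group, does not depend on the nitro: bromo in place of hydrogen gives a 9.9-fold lower number from compound 2 to compound 4 (1.00 log units; beyond the scatter), the same size as the step on adding nitro (a 9.9-fold lower number from compound 2 to compound 3 (1.00 log units; beyond the scatter)). The exchange of 4-nitrophenyl for 4-bromophenyl gives no change at the digits printed from compound 3 to compound 4 (within the scatter), so the nitrogen, the oxygens, the double bond and the hydrogen-bond acceptors counted on the nitro are not needed to hold the number on this core, and a single bromine atom serves equally well. No measurement is available to explain why these two different groups give the same number.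

On these data alone, two substituents at one place make a thin basis for a rule, and it remains open whether an amine, a carboxylic acid, a methoxy group or a longer alkyl chain at the same place would match bromo and nitro or fall back towards hydrogen. As far as these compounds go, it also remains open whether the gain from bromo carries over to the core of compound 1, where the hydroxyl group and the benzyl group differ from the core of compound 4.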